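Hydroxy in Place of Cyano on Compound 1

The source may hold more compounds than are shown below. What is called first, only, known or untested is meant among the compounds shown, and "the series" means these compounds.

In a functional assay on SH-SY5Y cells (Homo sapiens) for inhibition, read by sulforhodamine B assay (on this read-out lower numbers stand for stronger inhibition and higher numbers for weaker inhibition), compound 1 `COC(=O)CC/C(C)=C/Cc1c(OC)c(C)c2c(c1OCC#CCN1CCN(c3ccc(C#N)cc3)CC1)C(=O)OC2` stands at 37800 nM and compound 2 `COC(=O)CC/C(C)=C/Cc1c(OC)c(C)c2c(c1OCC#CCN1CCN(C(c3ccc(F)cc3)c3ccc(F)cc3)CC1)C(=O)OC2` at 25800 nM, two numbers within the usual scatter of each other. Compound 3 `COC(=O)CC/C(C)=C/Cc1c(OC)c(C)c2c(c1OCC#CCN1CCN(c3ccc(O)cc3)CC1)C(=O)OC2` has not yet been measured. It carries hydroxy in place of cyano on an aromatic carbon, para to a large group hydroxy in place of cyano on an aromatic carbon on the core of compound 1. Within the data shown here, no measured pair shows this change, so in this assay only a small expected step toward a lower number is assumed, a 1.5-fold lower number from compound 1 to compound 3 (0.18 log units; within the scatter) in size, possibly within the scatter. Compound 3 is estimated at 25000 nM with an expected range from 9000 nM to 60000 nM in this read-out.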

Compound 3, half-maximal inhibitory concentration: 46100 nM
Beside the measured number, compound 3's estimate is 1.8-fold (0.27 log units) below it; low and high end bracket the measured number.
By their numbers in this assay, from the lowest: compounds 2, 1 and 3 (each within the scatter of the next).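

In this assay, hydroxy in place of cyano on this aromatic carbon, para to a large group, gives a 1.2-fold higher number from compound 1 to compound 3 (0.09 log units; within the scatter), so the 4-cyanophenyl and 4-hydroxyphenyl compounds cannot be told apart on this read-out. Among these compounds, this is the first pair to test this position directly, and the exchange of these two groups does not separate the compounds. No measurement at hand bears on the reason for this result. From the compounds shown here alone, whether an amine or a carboxylic acid on the same carbon would give a step beyond the scatter remains open.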